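The source may report more compounds than this note shows. Statements on the series, on what has been measured and on what is new or still open speak of the compounds shown alone.

Compounds measured so far:
compound 1, `CCCCCCCCc1ccc(NC(=O)C(N)C(C)(C)O)cc1`, 2100 nM in an assay on isolated protein for inhibition of sphingosine kinase 1 (Homo sapiens), read by mobility shift assay; a lower number here means a stronger inhibitor, a higher number a weaker inhibitor
compound 2, `CCCCCCCCc1ccc(NC(=O)[C@@H](N)[C@@H](C)O)cc1`, 650 nM in this assay

Compound 2 holds the lowest number of the two; its nearest neighbour is compound 1, and the step of a 3.2-fold lower number from compound 1 to compound 2 (0.51 log units; beyond the scatter) lies beyond the scatter. Compound 3, `CCCCCCCCc1ccc(NC[C@@H](N)CO)cc1`, has not been measured in this assay. It differs from compound 2 by 2-amino-3-hydroxypropyl in place of (1-amino-2-hydroxypropyl)carbonyl on a nitrogen on an aromatic ring. For the measured compounds named here, the single measured step, from compound 1 to compound 2, concerns a change within the side chain while the carbonyl is kept; no measured step covers removal of the carbonyl, so that step gives only a loose guide. A moderate rise in the number, beyond the scatter, is expected for compound 3, though the direction is uncertain. The estimate for compound 3 in this assay is 1500 nM, between 300 nM and 8000 nM, an expected step of a 2.3-fold higher number from compound 2 to compound 3 (0.36 log units; beyond the scatter).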

Compound 3, half-maximal inhibitory concentration: 5000 nM
Compound 3: middle estimate off by 3.3-fold (0.52 log units), on the low side; the range from low to high includes it.
By their numbers in this assay, from the lowest: compound 2; then compound 1; then compound 3.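

Replacing the (1-amino-2-hydroxypropyl)carbonyl on this nitrogen with 2-amino-3-hydroxypropyl gives a 7.7-fold higher number from compound 2 to compound 3 (0.89 log units; beyond the scatter) in this assay, so the group on the nitrogen on an aromatic ring matters as well as the substituents further along the side chain. The step comes with the loss of the carbonyl, while the count of hydrogen-bond donors stays the same in the group that leaves and the group that enters, so that count does not follow the change. No measurement at hand explains why the number rises.

The two groups also differ in the rest of the chain. These compounds do not separate the loss of the carbonyl from that difference. From the compounds shown here alone, how a sulfonyl on this nitrogen, or a carboxylic acid in place of the hydroxyl, would behave also remains unknown from these compounds.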